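Adding a Phenyl Ring to Two Small Aromatic Cores

A few compounds are considered here, and "the series" means these few. Any claim that something is new, unique, unknown or untested is made for them only; others in the source may bear on it.

The read-out here is a functional assay on the whole organism for inhibition, with Rattus norvegicus as the target, with stated times of 1 h and 3.5 h, at a dose of 100 mg/kg by the oral route; on this read-out lower numbers stand for less inhibition and higher numbers for more inhibition at the one dose given (going by the name of the read-out). Compound 2 `CNc1nccc(C(C)(C)C)n1` gives 34% in this assay, and compound 1 `CNc1ncc(-c2ccccc2)c(C(C)(C)C)n1` gives 37%. The change between them is phenyl in place of hydrogen on an aromatic carbon, and the step is a number 3 percentage points higher from compound 2 to compound 1 (within the scatter).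

Compound 3 `Cc1ncnnc1-c1ccccc1` belongs to a different core; how the two cores differ is not broken down here. In this assay compound 3 gives < 5%, which is a limit of the assay and not a number (the limit of < 5% in this assay, at which 1 of the 3 values shown sits).

Compound 4 `Cc1nc(-c2ccccc2)nnc1-c1ccccc1` differs from compound 3 by phenyl in place of hydrogen on an aromatic carbon. This is the same kind of change as that from compound 2 to compound 1, but the surroundings differ: here the phenyl enters between two ring nitrogen atoms, meta to a methyl group and para to a phenyl group, whereas in compound 1 it sits ortho to a tert-butyl group and para to a methylamino group.

Among the measured compounds shown here, the only measured example of this change, a number 3 percentage points higher from compound 2 to compound 1 (within the scatter), stayed within the scatter, so compound 4 is expected to move little from compound 3, giving an estimated step of a number at least 5 percentage points higher from compound 3 to compound 4 (that floor lies within the scatter). Compound 4 is therefore estimated to give 10% in this assay, with a range from 0% to 30%.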

Compound 4, a percentage reported as inhibition, in the whole organism at one dose (the size of the read-out at that dose, not a potency): < 5%
Compound 4 gave a limit, no number; the forecaster's own chance of this, stated with the estimate: 45%; middle value at least 5 percentage points from the limit.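

Compound 3 and compound 4 each give a limit of the assay and not a number, so no step between them can be read: the limit of < 5% in this assay, at which 2 of the 4 values shown sit.

From the compounds shown here alone, whether phenyl in place of hydrogen on an aromatic carbon changes the result in this assay on the core of compound 3 stays open.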